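Swapping octyloxy for benzylsulfanyl on a cytotoxicity read-out

A few compounds are considered here, and "the series" means these few. Any claim that something is new, unique, unknown or untested is made for them only; others in the source may bear on it.

Compound 1 `CCCCCCCCOc1nc(N)nc2c1ncn2/C=C1/CC1(CO)CO` stands only at a limit in an ADME assay on Akata cells (Homo sapiens) for cytotoxicity, with a stated time of 7 days; on this read-out lower numbers stand for higher toxicity in this test and higher numbers for lower toxicity in this test: compound 1 gives > 20000 nM, a limit of the assay rather than a number. Compound 2 `CCCCCOc1nc(N)nc2c1ncn2/C=C1/CC1(CO)CO` gives > 20000 nM in this assay, again a limit. Going by the values given here, the step that the two limits leave unreadable from compound 1 to compound 2 is thus unreadable, and the limit of > 20000 nM in this assay, at which 2 of the 2 values shown sit, is the only evidence at hand. Compound 3 `Nc1nc(SCc2ccccc2)c2ncn(/C=C3/CC3(CO)CO)c2n1` differs from compound 1 by benzylsulfanyl in place of octyloxy on an aromatic carbon. With no readable step to lean on, the change is expected to stay within the scatter, a number no higher from compound 1 to compound 3 (the limit leaves the size open). Compound 3 is therefore estimated at 20000 nM, between 7000 nM and 60000 nM.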

Compound 3, half-maximal cytotoxic concentration: > 20000 nM
Compound 3: a limit, no number; the forecaster's own chance of this, stated with the estimate: 65%; the middle value sits exactly at the limit.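

No step can be read from compound 1 or compound 2 to compound 3, since each value is a limit rather than a number: the limit of > 20000 nM in this assay, at which 3 of the 3 values shown sit.

Going by these compounds, whether octyloxy, pentyloxy and benzylsulfanyl differ at all in this assay stays open.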